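Swapping an Ester for a Thioether on the Anilide Ring

The compounds below may be only part of what the source reports. "The series", "measured", "known", "first", "only" and "open" are said of these compounds alone.

Measured compounds in an ADME assay on PC-3 cells (Homo sapiens) for cytotoxicity, read by WST assay, tested at 100 uM; a higher number here means more inhibition at the concentration tested (going by the name of the read-out), a lower number less inhibition:
compound 1, `COC(=O)c1cccc(NC(=O)C2CCCN(C(=O)c3cc(C(F)(F)F)cc(C(F)(F)F)c3)C2)c1`, 0%
compound 2, `O=C(Nc1ccc(Cl)cc1)C1CCCN(C(=O)c2cccc(-c3nccs3)c2)C1`, 32%
compound 3, `CS(=O)(=O)Nc1cccc(C(=O)N2CCCC(C(=O)Nc3ccc(Cl)cc3)C2)c1`, 3%

Compound 1 gives the lowest of the three numbers; compound 3 lies within the scatter of it, while compound 2 stands beyond it. For the measured compounds named here, the only measured step, a number 29 percentage points lower from compound 2 to compound 3 (beyond the scatter), alters a different part of the shared core and so does not bear directly on the change considered here. Compound 4, `CSc1cccc(NC(=O)C2CCCN(C(=O)c3cc(C(F)(F)F)cc(C(F)(F)F)c3)C2)c1`, differs from compound 1 by methylsulfanyl in place of methoxycarbonyl on an aromatic carbon. Going by the values given here, with no step of this kind measured and compound 1 already at the lowest number seen, the expected step of a number 8 percentage points higher from compound 1 to compound 4 (within the scatter) is none beyond the scatter. Compound 4 is therefore estimated at 8% in this assay, within a range of 0% to 25%.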

Compound 4, a percentage reported as inhibition, at one concentration (the size of the read-out at that concentration, not a potency): 0%
Compound 4: the middle estimate sits 8 percentage points above what was measured; the measured number falls inside the stated range.
By their numbers in this assay, from the lowest: compounds 1, 4 and 3 (each within the scatter of the next); then compound 2.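

In this assay, for the compounds shown here, methylsulfanyl in place of methoxycarbonyl, on this aromatic carbon meta to a large group, gives no change at the digits printed from compound 1 to compound 4 (within the scatter) and is the first step read at this position. Both compounds rest at the lowest number seen, so the swap brings no rise in inhibition, and any fall would not show. Nothing measured here explains this result.

On these data alone, whether an amine or a carboxylic acid at this position would raise the number remains open. So does whether this swap would matter on a core that starts higher, such as that of compound 2.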